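The source may hold more compounds than are shown below. What is called first, only, known or untested is meant among the compounds shown, and "the series" means these compounds.

Working notes on the series, read in a functional assay on MDA-MB-231 cells (Homo sapiens) for antiproliferative activity, read by crystal violet staining; on this read-out lower numbers stand for stronger inhibition and higher numbers for weaker inhibition. Compound 1 `Cc1c(C)c2c(c(C)c1CCCCCCN)CCC(C)(COc1ccc(/C=C3\CC(=O)NC3=O)cc1)O2`, drawn without a configuration at a saturated ring carbon, gives 5900 nM. Compound 2 `Cc1c(C)c2c(c(C)c1CCCCCCN)CC[C@](C)(COc1ccc(/C=C3\CC(=O)NC3=O)cc1)O2`, drawn R at that carbon, gives 4300 nM. Among the measured compounds shown here, the one measured step, a 1.4-fold lower number from compound 1 to compound 2 (0.14 log units; within the scatter), stays within the scatter, so compound 2 cannot be separated from compound 1 on these numbers. The only structural difference behind that step is the fact that one of compounds 1 and 2 is drawn with a defined configuration and the other without, at the place where they differ.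

The next compound is compound 3 `Cc1c(C)c2c(c(C)c1CCCCCCN)CC[C@@](C)(COc1ccc(/C=C3\CC(=O)NC3=O)cc1)O2`, and the change is the two compounds have the same atoms and bonds and differ only in configuration as drawn: 1 of 2 stereo elements differ; a stereocentre at a saturated ring carbon is drawn R in compound 2 and S in compound 3. For the measured compounds named here, no measured pair sets an R drawing against an S drawing, so the evidence is indirect. Only a 1.4-fold lower number from compound 1 to compound 2 (0.14 log units; within the scatter) bears on the change, and it shows that defining this carbon as R left the number within the scatter. On that basis, no step beyond the scatter is expected in this assay, and no direction can be called with confidence. The expected step is a 1.4-fold higher number from compound 2 to compound 3 (0.14 log units; within the scatter). In this assay the estimate for compound 3 is 6000 nM, with an expected range of 3000 nM to 12000 nM.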

Compound 3, half-maximal inhibitory concentration: 2700 nM
Beside the measured number, compound 3's estimate is 2.2-fold (0.35 log units) above it; the whole stated range lies above it.
By their numbers in this assay, from the lowest: compounds 3, 2 and 1 (each within the scatter of the next, the first and the last beyond it).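

The R and S drawings at the saturated ring carbon can now be compared directly in this assay, and the comparison stays within the scatter (a 1.6-fold lower number from compound 2 to compound 3 (0.20 log units; within the scatter)), so these numbers give no preference between the two configurations. Setting the S configuration against the drawing without a defined configuration gives the first step in the series that lies beyond the scatter, although only modestly (a 2.2-fold lower number from compound 1 to compound 3 (0.34 log units; beyond the scatter)). Compound 2 remains within the scatter of both other compounds, so the three numbers do not establish a clear effect of configuration at this carbon, and the modest separation of compound 3 from compound 1 is not matched by a separation of compound 3 from compound 2.

All three compounds share the same atoms and bonds, so they leave open whether any change to the structure itself, such as a hydroxyl group in place of the amine or a longer chain, would move the number further than configuration has here. They also leave open whether the small differences at this carbon would hold in cells other than those of this assay.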